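Swapping the amine at the end of the propoxy chain

A few compounds are considered here, and "the series" means these few. Any claim that something is new, unique, unknown or untested is made for them only; others in the source may bear on it.

Compound 1 `COc1cc2c(Oc3ccc(NC(=O)c4nn(-c5ccccc5)c(=O)cc4C)cc3F)ccnc2cc1OCCCN1CCCC1` was tested in a functional assay on A549 cells (Homo sapiens) for inhibition, read by MTT assay, with a stated time of 72 h (on this read-out lower numbers stand for stronger inhibition and higher numbers for weaker inhibition), where compound 1 gives 370 nM. Its companion compound 2 `Cc1cc(=O)n(-c2ccccc2)nc1C(=O)Nc1ccc(Oc2ccnc3cc(OCCCN4CCC(C)CC4)ccc23)c(F)c1` gives 320 nM in this assay. On these two numbers compound 1 cannot be set apart from compound 2, since the gap between them lies within the usual scatter of such measurements. The next compound, compound 3 `COc1cc2c(Oc3ccc(NC(=O)c4nn(-c5ccccc5)c(=O)cc4C)cc3F)ccnc2cc1OCCCN1CCN(C)CC1`, has not yet been measured. It differs from compound 1 in one place: 4-methylpiperazin-1-yl in place of pyrrolidin-1-yl on a saturated chain carbon, three bonds along the chain from an oxygen on an aromatic ring. For the measured compounds named here, no measured pair shows what this exchange does on the shared core, so the expectation for compound 3 rests on the change alone. The author expects the step from compound 1 to compound 3 in this assay, a 1.1-fold higher number from compound 1 to compound 3 (0.03 log units; within the scatter), to be small and not beyond the scatter in either direction. For compound 3 the author therefore estimates 400 nM, with a range from 150 nM to 1100 nM.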

Compound 3, half-maximal inhibitory concentration: 350 nM
Beside the measured number, compound 3's estimate is 1.1-fold (0.06 log units) above it; low and high end bracket the measured number.
By their numbers in this assay, from the lowest: compounds 2, 3 and 1 (each within the scatter of the next).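

In this assay, for the compounds shown here, the exchange of pyrrolidin-1-yl for 4-methylpiperazin-1-yl, on a saturated chain carbon three bonds along the chain from an oxygen on an aromatic ring, gives a 1.1-fold lower number from compound 1 to compound 3 (0.02 log units; within the scatter) and so provides the first direct reading of this change on the shared core. At this position, a six-membered non-aromatic ring with 2 hetero atoms can take the place of a five-membered one with 1 hetero atom with no difference that this read-out can resolve. Nothing available explains this outcome.

The compounds shown leave open how a morpholin-4-yl group or an open-chain dimethylamino group at the end of the propyl chain would read in this assay and what a longer chain carrying these amines would do. They also leave open whether the exchange would stay this small on a different core.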